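The compounds below may be only part of what the source reports. "The series", "measured", "known", "first", "only" and "open" are said of these compounds alone.

Two amides built on the same core have been measured in an assay on isolated protein for inhibition of phosphodiesterase 4A (Sus scrofa); a higher number here means a weaker inhibitor, a lower number a stronger inhibitor. Compound 1 `COc1ccc(C(=O)Nc2c(F)cccc2Cl)cc1OC1CCCC1` gives 240 nM. Compound 2 `COc1ccc(C(=O)Nc2c(C)nsc2C)cc1OC1CCCC1`, which carries a different ring on the amide nitrogen, gives 500 nM in this assay. Among the measured compounds shown here, the single measured step, a 2.1-fold higher number from compound 1 to compound 2 (0.32 log units; beyond the scatter), places compound 2 at the higher of the two numbers, with compound 1 as its only neighbour, lower by that modest margin.

Compound 3 `COc1ccc(C(=O)Nc2c(C)nsc2Br)cc1OC1CCCC1` has not yet been measured. It differs from compound 2 in one place: bromo in place of methyl on an aromatic carbon. For the measured compounds named here, no measured step bears directly on this change; the one step at hand exchanges the whole ring on the amide nitrogen rather than a single group on that ring, and even that exchange was modest in size. The two numbers therefore give no ground for a move in either direction for compound 3. In this assay compound 3 is expected to give about 500 nM, within a range of 200 nM to 1300 nM. The expected step is no change at the digits printed from compound 2 to compound 3 (within the scatter), which would remain within the usual scatter.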

Compound 3, half-maximal inhibitory concentration: 500 nM
For compound 3 middle estimate and measured number coincide at the digits printed; the range from low to high includes it.
By their numbers in this assay, from the lowest: compound 1; then compounds 2 and 3 (each within the scatter of the next).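

In this assay, the position next to the ring sulfur takes bromo in place of methyl with no change at the digits printed from compound 2 to compound 3 (within the scatter), and this is the first change shown that replaces a single group and leaves the ring on the amide nitrogen in place. Exchanging 2-chloro-6-fluorophenyl for 5-bromo-3-methyl-1,2-thiazol-4-yl gives a 2.1-fold higher number from compound 1 to compound 3 (0.32 log units; beyond the scatter), a step of the same printed size as the one for 3,5-dimethyl-1,2-thiazol-4-yl, a 2.1-fold higher number from compound 1 to compound 2 (0.32 log units; beyond the scatter), so at this position methyl and bromo leave the distance from compound 1 as it was. Nothing measured here explains why these two groups read alike.

Methyl and bromo are each a single heavy atom, so it remains open whether this position would keep the same number with an amine, a carboxylic acid or a longer chain such as propyl. Also open, going by these compounds, is whether the methyl group two ring bonds away can be exchanged in the same way, and whether any group on this ring would bring the number below that of compound 1.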